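Amide substituent change from compound 2 to compound 4

The source may report more compounds than this note shows. Statements on the series, on what has been measured and on what is new or still open speak of the compounds shown alone.

Compound 2 `O=C(NC1(c2ccccc2)CC1)c1c(CN2CCC(N3CCCCC3)CC2)c(-c2cccc(C(F)(F)F)c2)nc2ccccc12` gives 50 nM in an assay on HEK293 cells for antagonist activity at transient receptor potential cation channel subfamily V member 4 (Homo sapiens), read by FLIPR and calcium flux, with a stated time of 10 min (a lower number here means a stronger inhibitor, a higher number a weaker inhibitor), the lowest of the three numbers in hand. Compound 3 `Cc1ccc(-c2nc3ccccc3c(C(=O)N[C@@H](C)c3ccccc3)c2CN2CCC(N3CCCCC3)CC2)cc1` gives 1580 nM in this assay, and compound 1 `C[C@H](NC(=O)c1c(CN2CCC(N(C)C)CC2)c(-c2cccc(C(F)(F)F)c2)nc2ccccc12)c1ccccc1` gives 2510 nM; both of these stand beyond the scatter away from compound 2. Compound 4 `CC(C)[C@H](NC(=O)c1c(CN2CCC(N3CCCCC3)CC2)c(-c2cccc(C(F)(F)F)c2)nc2ccccc12)c1ccccc1` has not yet been measured. Within the data shown here, it differs from compound 2 in one place: 2-methyl-1-phenylpropyl in place of 1-phenylcyclopropyl on an amide-type nitrogen No measured pair isolates this change, so the outlook rests on compound 2 alone; compound 1 and compound 3 carry a different substituent on that nitrogen together with other changes and give weaker numbers. A moderate loss is expected, with the estimated step of a 6.0-fold higher number from compound 2 to compound 4 (0.78 log units; beyond the scatter) lying beyond the scatter. Compound 4 is estimated at 300 nM, within 60 nM to 1500 nM.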

Compound 4, half-maximal inhibitory concentration: 130 nM
Compound 4: the middle estimate sits 2.3-fold (0.36 log units) above what was measured; the measured number falls inside the stated range.
By their numbers in this assay, from the lowest: compound 2; then compound 4; then compounds 3 and 1 (each within the scatter of the next).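

In this assay, 2-methyl-1-phenylpropyl in place of 1-phenylcyclopropyl on the amide-type nitrogen gives a 2.6-fold higher number from compound 2 to compound 4 (0.41 log units; beyond the scatter), a modest step and the only reading among these compounds that isolates this position. The three-membered ring is therefore not required for activity at this level: compound 4 still gives 130 nM. No measurement at hand explains the step.

Still open, going by these compounds, is how the opposite configuration of the 2-methyl-1-phenylpropyl stereocentre would read. Also open, on these data alone, is how 1-phenylcyclobutyl on the same nitrogen would compare.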